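This account rests on a few compounds, and the source may have more. Where it says the series, first, only, none or still open, it means among the compounds named here.

Measured compounds:

Compound 1 `O=C(C1COc2ccccc2O1)N1N=C(c2ccc(Br)cc2)CC1c1ccccc1F` — 8030 nM in a functional assay on WM 266-4 cells (Homo sapiens) for inhibition, read by MTT assay, with a stated time of 24 h; a higher number here means a weaker inhibitor of growth, a lower number a stronger inhibitor of growth
Compound 2 `COc1ccc(C2CC(c3ccc(Br)cc3)=NN2C(=O)C2COc3ccccc3O2)cc1` — 9010 nM in this assay
Compound 3 `COc1ccc(C2=NN(C(=O)c3ccc4c(c3)OCCO4)C(c3ccc(OC)cc3)C2)cc1` — 9890 nM in this assay

Going by the values given here, all three numbers sit within the usual scatter of one another, so no compound can be called stronger or weaker than the others. Compound 1 and compound 2 share one core and differ by 2-fluorophenyl in place of 4-methoxyphenyl on a saturated ring carbon; this change gave a 1.1-fold lower number from compound 2 to compound 1 (0.05 log units; within the scatter). Compound 3 has a different core, and how the two cores differ is not broken down here.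

Compound 4 `COc1ccc(C2=NN(C(=O)c3ccc4c(c3)OCCO4)C(c3ccccc3F)C2)cc1` is not yet measured. It differs from compound 3 by 2-fluorophenyl in place of 4-methoxyphenyl on a saturated ring carbon. This is the same kind of change as from compound 2 to compound 1, though the ring atom two bonds away bears a 4-methoxyphenyl group in compound 3 and a 4-bromophenyl group in compound 2. Because the earlier step gave a 1.1-fold lower number from compound 2 to compound 1 (0.05 log units; within the scatter), the step from compound 3 to compound 4 in this assay is expected to be of similar, small size, a 1.1-fold lower number from compound 3 to compound 4 (0.04 log units; within the scatter). Compound 4 is therefore estimated at 9000 nM, likely between 4000 nM and 20000 nM.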

Compound 4, concentration for 50% growth inhibition: 3470 nM
Beside the measured number, compound 4's estimate is 2.6-fold (0.41 log units) above it; measured number below the stated range.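

In this assay, putting 2-fluorophenyl in place of 4-methoxyphenyl on the saturated ring carbon gave a 2.9-fold lower number from compound 3 to compound 4 (0.45 log units; beyond the scatter), a modest step that stands clear of the usual scatter. Set beside the same change on the other core, this step cannot be told apart from the earlier one: the same change on two cores in this assay, a 1.1-fold lower number (0.05 log units; within the scatter) from compound 2 to compound 1 and a 2.9-fold lower number (0.45 log units; beyond the scatter) from compound 3 to compound 4, 2.5-fold (0.40 log units) apart, within the scatter of two such steps. Going by these compounds alone, the data therefore give no sign that the core alters what this change does, but they do not prove that its effect carries over unchanged, as only one of the two steps lies beyond the scatter and two cores are a small sample.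

The compounds shown leave open whether the step would hold on a third core, and whether it depends on the fluorine atom, on the loss of the methoxy group, or on both. They also leave open what a different group on that ring carbon would do, such as a phenyl ring bearing an amine or a carboxylic acid.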